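Compound 2 at the limit, and a longer side group

A few compounds are considered here, and "the series" means these few. Any claim that something is new, unique, unknown or untested is made for them only; others in the source may bear on it.

- Compound 1 `FC(F)(F)c1c(CN2CCCC(c3ccccc3)C2)ccn2c(CC3CC3)nnc12`: 45000 nM
- Compound 2 `Fc1ccc(C2CCN(Cc3ccn4c(CC5CC5)nnc4c3C(F)(F)F)CC2)c(F)c1`: < 600 nM

Both compounds were tested in a physicochemical assay for solubility, read by HPLC, measured as kinetic solubility, at pH 7; a lower number here means a less soluble compound, a higher number a more soluble compound. Compound 2 reads < 600 nM, and this is a limit of the assay, not a number. Compound 3 `Fc1ccc(COC2CCN(Cc3ccn4c(CC5CC5)nnc4c3C(F)(F)F)CC2)c(F)c1` differs from compound 2 in one place: (2,4-difluorobenzyl)oxy in place of 2,4-difluorophenyl on a saturated ring carbon. Here (2,4-difluorobenzyl)oxy stands in place of 2,4-difluorophenyl on a saturated ring carbon. Within the data shown here, no measured pair shows this change, so any expectation is uncertain. Compound 1, at 45000 nM, shows that a compound sharing this core can read far higher. The expected step of an at least 2.5-fold higher number from compound 2 to compound 3 (0.39 log units; beyond the scatter) is a modest rise in this assay. Compound 3 is expected at 1500 nM, with an estimated range of 500 nM to 15000 nM.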

Compound 3, solubility: 3000 nM
Beside the measured number, compound 3's estimate is 2.0-fold (0.30 log units) below it; the range from low to high includes it.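

In this assay, (2,4-difluorobenzyl)oxy in place of 2,4-difluorophenyl on a saturated ring carbon goes with an at least 5.0-fold higher number from compound 2 to compound 3 (0.69 log units; beyond the scatter). Among these compounds, this is the first measured change at this position, and it shows that the longer, oxygen-bearing group gives a reading clear of the limit. The true size of the step stays unknown because compound 2 sits at a limit of the assay: the limit of < 600 nM in this assay, at which 1 of the 3 values shown sits.

The compounds shown leave open whether the oxygen or the added length goes with the rise. A plain benzyl group or an amine on this ring carbon could help separate the two.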